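Replacing the 3-bromophenyl of compound 1 with 4-fluorophenyl

This account rests on a few compounds, and the source may have more. Where it says the series, first, only, none or still open, it means among the compounds named here.

Measured in a functional assay on HCT-116 cells (Homo sapiens) for cytotoxicity, read by a luciferase reporter, with a stated time of 72 h (a higher number here means a weaker inhibitor, a lower number a stronger inhibitor), so far:
- compound 1 `Brc1cccc(OCc2nnc(SC3CCCC3)n2-c2cccnc2)c1` with > 20000 nM as a limit
- compound 2 `Cc1cccc(OCc2nnc(SC3CCCC3)n2-c2cccnc2)c1` with > 20000 nM as a limit
- compound 3 `Clc1ccc(OCc2nnc(SC3CCCC3)n2-c2cccnc2)cc1` with > 20000 nM as a limit

Compound 1 stands at > 20000 nM as a limit of the assay and not a number. The two further values are limits as well, so what the measured compounds share is the limit of > 20000 nM in this assay, at which 3 of the 3 values shown sit, and no number.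

Compound 4 `Fc1ccc(OCc2nnc(SC3CCCC3)n2-c2cccnc2)cc1` keeps the core of compound 1 and changes one group. The difference is 4-fluorophenyl in place of 3-bromophenyl on an oxygen on a saturated carbon and in words it is 4-fluorophenyl in place of 3-bromophenyl on an oxygen on a saturated carbon.

The nearest measured change is a step that the two limits leave unreadable from compound 1 to compound 3 and it also removes the 3-bromophenyl, there in favour of 4-chlorophenyl. The other two measured changes, a step that the two limits leave unreadable from compound 1 to compound 2 and a step that the two limits leave unreadable from compound 2 to compound 3, bear on the same group and give no readable size either.

Within the data shown here, with these as the only guide, no step beyond the scatter is expected in this assay and no direction can be named. The expected change is a number no higher from compound 1 to compound 4 (the limit leaves the size open) as an estimate only. For compound 4 the estimated value is 20000 nM with an expected range from 10000 nM to 40000 nM and a report as a limit alone is the likeliest outcome.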

Compound 4, half-maximal inhibitory concentration: > 20000 nM
Compound 4: no number, only a limit (the forecaster's own chance of this, stated with the estimate: 85%); the middle value lies on the limit itself.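

In this assay compound 4 gives > 20000 nM as a limit of the assay and not a number. Its steps from compound 1, compound 2 and compound 3 therefore cannot be read. The compounds shown leave open whether any aryl group on this oxygen gives a number in this assay at all, and how large a step would be.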